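Hydroxymethyl to 1-hydroxy-1-methylethyl: hepatocyte clearance notes

The source may report more compounds than this note shows. Statements on the series, on what has been measured and on what is new or still open speak of the compounds shown alone.

Measured so far in an ADME assay on cells (Hepatocyte, Homo sapiens) for pharmacokinetics; on this read-out higher numbers stand for fast clearance and lower numbers for slow clearance:
compound 1 `CC(C)n1nc(N)c2cnc(Nc3ccnc(-c4cnn(S(=O)(=O)C5CC5)c4)n3)cc21`: 8.4 mL/min/kg
compound 2 `CC(C)n1nc(N2CC(CO)C2)c2cnc(Nc3ccnc(-c4cnn(S(=O)(=O)C5CC5)c4)n3)cc21`: 13 mL/min/kg

Compound 2 gives the highest of the two numbers in this assay, but its nearest neighbour is compound 1 and the gap a 1.5-fold higher number from compound 1 to compound 2 (0.19 log units; within the scatter) is within the scatter, so the two read as equal. Compound 3 `CC(C)n1nc(N2CC(C(C)(C)O)C2)c2cnc(Nc3ccnc(-c4cnn(S(=O)(=O)C5CC5)c4)n3)cc21` is not yet measured. It differs from compound 2 in one place: 1-hydroxy-1-methylethyl in place of hydroxymethyl on a saturated ring carbon. Within the data shown here, no measured step touches this position; the only step known, from compound 1 to compound 2, exchanges the group on the aromatic carbon and stays within the scatter. Nothing in the measured pair therefore points to a step beyond the scatter in this assay for compound 3, in either direction. The estimate for compound 3 is 14 mL/min/kg, expected between 7 mL/min/kg and 28 mL/min/kg, meaning an expected step of a 1.1-fold higher number from compound 2 to compound 3 (0.03 log units; within the scatter) that stays within the scatter.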

Compound 3, clearance: 7.1 mL/min/kg
The estimate for compound 3 lay 2.0-fold (0.29 log units) above the measured number; low and high end bracket the measured number.
By their numbers in this assay, from the lowest: compounds 3, 1 and 2 (each within the scatter of the next).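

In this assay, among these compounds, 1-hydroxy-1-methylethyl in place of hydroxymethyl on a saturated ring carbon of the four-membered non-aromatic ring gives a 1.8-fold lower number from compound 2 to compound 3 (0.26 log units; within the scatter) and stays within the scatter, the first measured step at this position. 3-(1-hydroxy-1-methylethyl)azetidin-1-yl in place of amino on an aromatic carbon gives a 1.2-fold lower number from compound 1 to compound 3 (0.07 log units; within the scatter) and is also within the scatter, so the three compounds read as equal on this clearance read-out. No measurement bears on why these numbers fall as they do.

Going by these compounds, whether a carboxylic acid or a primary amine on this ring carbon, or a longer chain bearing the hydroxyl, would give a step beyond the scatter stays open. The compounds shown also leave open whether the same exchange behaves alike on any other core.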